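The source may report more compounds than this note shows. Statements on the series, on what has been measured and on what is new or still open speak of the compounds shown alone.

Of the compounds shown here, three built on one shared core have been measured in a functional assay on CHO.K1 cells for antagonist activity at prostaglandin D2 receptor 2 (Homo sapiens), read by GTPgammaS binding, with a stated time of 1 h; on this read-out higher numbers stand for weaker inhibition and lower numbers for stronger inhibition. Compound 1 `Cc1c(Cc2ccc(C(F)(F)F)cc2S(=O)(=O)c2ccccc2)c2c(n1CC(=O)O)CCNC2=O` gives 13 nM in this assay. Compound 2 `COc1ccc(S(=O)(=O)c2ccccc2)c(Cc2c3c(n(CC(=O)O)c2C)CCNC3=O)c1` gives 3.6 nM in the same assay. Compound 3 `Cc1c(Cc2ccccc2S(=O)(=O)c2cccc(Cl)c2)c2c(n1CC(=O)O)CCNC2=O` gives 4 nM. Among the three numbers compound 3 holds the second highest; its gap to compound 2 lies within the usual scatter, so no order can be read between these two, whereas compound 1 shows a higher number than compound 3 by a margin beyond the scatter.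

Compound 4 `Cc1c(Cc2ccccc2Oc2ccccc2)c2c(n1CC(=O)O)CCNC2=O` has not yet been measured. It differs from compound 3 in one place: phenoxy in place of (3-chlorophenyl)sulfonyl on an aromatic carbon

Going by the values given here, no measured pair in this set carries the same change, so its effect can only be anticipated. The number for compound 4 is expected to come out somewhat higher than that of compound 3, a step of a 3.8-fold higher number from compound 3 to compound 4 (0.57 log units; beyond the scatter), though a result within the scatter cannot be excluded. Compound 4 is therefore estimated at 15 nM, with a range from 4 nM to 60 nM.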

Compound 4, half-maximal inhibitory concentration: 530 nM
Compound 4: middle estimate off by 35-fold (1.55 log units), on the low side, outside the stated range (above it).
By their numbers in this assay, from the lowest: compounds 2 and 3 (each within the scatter of the next); then compound 1; then compound 4.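

In this assay, putting phenoxy in place of (3-chlorophenyl)sulfonyl on an aromatic carbon, ortho to a large group, brings a 130-fold higher number from compound 3 to compound 4 (2.12 log units; beyond the scatter), so this position is far from indifferent to the group it carries. The three earlier compounds all hold a sulfonyl-linked aromatic ring here and differ only in substituents on the aromatic rings, so they could not show what happens when that link itself is replaced. Nothing at hand accounts for the size of this step.

The change removes the sulfonyl link and the chlorine together, so the compounds shown do not tell how much of the step belongs to each. Also open, as far as these compounds go, is how a 3-chlorophenoxy group, a benzoyl group or a phenylamino group would read at this position.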